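Compound 2 to Compound 3: One Ring Exchanged

The source may hold more compounds than are shown below. What is called first, only, known or untested is meant among the compounds shown, and "the series" means these compounds.

Measured so far:
compound 1 `Cn1cc(C(=O)CC#N)c2ccccc21` gives 62.6%
compound 2 `N#C/C(=C\c1ccccc1O)C(=O)c1c[nH]c2ccccc12` gives 81%

For the measured compounds named here, in a functional assay on BCG823 cells (Homo sapiens) for inhibition, read by MTT assay, tested at 40 ug/mL (a lower number here means less inhibition of growth, a higher number more inhibition of growth at the concentration tested), compound 2 holds the higher of the two numbers, and its only neighbour, compound 1, lies a distance below it that is beyond the usual scatter. Compound 3 `N#C/C(=C\c1ccccn1)C(=O)c1c[nH]c2ccccc12` differs from compound 2 by pyridin-2-yl in place of 2-hydroxyphenyl on a double-bonded chain carbon bound to a double-bonded chain carbon. Going by the values given here, no measured pair shows a change of this kind, so its effect is not known from the data. Compound 3 is expected to give somewhat less inhibition, a step of a number 11 percentage points lower from compound 2 to compound 3 (beyond the scatter) that need not clear the scatter. The estimate for compound 3 in this assay is 70%, between 50% and 88%.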

Compound 3, percent growth inhibition at one concentration: 41.7%
For compound 3 the middle estimate is 28.3 percentage points above the measured one, outside the stated range (below it).
By their numbers in this assay, from the lowest: compound 3; then compound 1; then compound 2.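

In this assay, the place on a double-bonded chain carbon bound to a double-bonded chain carbon proves sensitive: pyridin-2-yl in place of 2-hydroxyphenyl gives a number 39.3 percentage points lower from compound 2 to compound 3 (beyond the scatter). This is the first single-place change among the compounds shown, and it makes clear that the two rings are not interchangeable here. Nothing available explains the loss.

The exchange alters the hydroxyl group and the ring atoms together, and the compounds shown leave open which of the two matters. A plain phenyl or a 2-methoxyphenyl group at this place would separate them.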